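The source may report more compounds than this note shows. Statements on the series, on what has been measured and on what is new or still open speak of the compounds shown alone.

Measured so far:
Compound 1, `Cc1ccc(-c2cc(-c3ccccc3O)nc(N)n2)cc1`: > 128000 nM
Compound 2, `Nc1nc(-c2cccc(Cl)c2)cc(-c2ccccc2O)n1`: > 125000 nM

In an ADME assay on MT4 cells (Homo sapiens) for cytotoxicity, read by MTT assay, with a stated time of 5 days (on this read-out lower numbers stand for higher toxicity in this test and higher numbers for lower toxicity in this test), compound 1 gives > 128000 nM, which is a limit of the test rather than a number. In this assay compound 2 gives > 125000 nM, again only a limit. The step that the two limits leave unreadable from compound 1 to compound 2 therefore cannot be read. Compound 3, `Nc1nc(-c2cccs2)cc(-c2ccccc2O)n1`, differs from compound 2 in one place: thiophen-2-yl in place of 3-chlorophenyl on an aromatic carbon. No readable step bears on this change, so no shift beyond the scatter is expected. Compound 3 is estimated at 130000 nM, between 40000 nM and 300000 nM. The expected step that the limit leaves unreadable from compound 2 to compound 3 is thus one of no change, most likely ending again at a limit.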

Compound 3, half-maximal cytotoxic concentration: 5300 nM
Compound 3: middle estimate off by 25-fold (1.39 log units), on the high side, outside the stated range (below it).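

In this assay, the group on this aromatic carbon can clearly matter: the step between the two six-membered aromatic rings cannot be read, but thiophen-2-yl brings higher toxicity in this test, with an at least 23-fold lower number from compound 2 to compound 3 (1.37 log units; beyond the scatter) and an at least 24-fold lower number from compound 1 to compound 3 (1.38 log units; beyond the scatter). The full size of the first step stays unknown, as compound 2 gives only a limit: the limit of > 125000 nM in this assay, at which 1 of the 3 values shown sits. The same holds for the second step, as compound 1 also gives only a limit: the limit of > 128000 nM in this assay, at which 1 of the 3 values shown sits.

As far as these compounds go, whether the sulfur or the five-membered ring carries this shift remains open. So does what a furan-2-yl group or an amine would give at this place.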